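The source may hold more compounds than are shown below. What is called first, only, known or untested is meant among the compounds shown, and "the series" means these compounds.

In a functional assay on MDA-MB-231 cells (Homo sapiens) for inhibition, read by MTT assay, with a stated time of 72 h (on this read-out lower numbers stand for stronger inhibition and higher numbers for weaker inhibition), compound 1 (`CC1=NN(c2ccccc2)C(=O)[C@]12C(=O)C=CC[C@@H]2c1ccc(C)cc1`) gives 6240 nM. In this assay, compound 2 (`CC1=NN(c2ccc(C)cc2)C(=O)[C@@]12C(=O)C=CC[C@H]2c1ccc(C)cc1`) gives 9200 nM. These two numbers lie within the usual scatter of each other, so compound 2 cannot be told apart from compound 1 on this read-out.

Compound 3 (`CC1=NN(c2ccc(C)cc2)C(=O)[C@]12C(=O)C=CC[C@@H]2c1ccc(C)cc1`) has not yet been measured. Set against compound 2, it shows (the two compounds have the same atoms and bonds and differ only in configuration as drawn: 2 of 2 stereo elements differ (all stereocentres are inverted: mirror images); a stereocentre at a saturated ring carbon is drawn R in compound 2 and S in compound 3; a stereocentre at a saturated ring carbon is drawn S in compound 2 and R in compound 3). The two compounds have the same atoms and bonds and are mirror images: one stereocentre at a saturated ring carbon is drawn R in compound 2 and S in compound 3, and the other is drawn S in compound 2 and R in compound 3.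

For the measured compounds named here, no measured pair shows what such an inversion does in this assay, so no direction is favoured, and the range is kept wide. The expected result is no change beyond the scatter, given as a 1.2-fold lower number from compound 2 to compound 3 (0.06 log units; within the scatter). For compound 3, the estimated value is 8000 nM, with an expected range of 3000 nM to 20000 nM.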

Compound 3, half-maximal inhibitory concentration: 57200 nM
Estimate against measurement, compound 3: 7.2-fold (0.85 log units) below; the measured number lies above the stated range.
By their numbers in this assay, from the lowest: compounds 1 and 2 (each within the scatter of the next); then compound 3.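

In this assay, inverting both stereocentres gives a 6.2-fold higher number from compound 2 to compound 3 (0.79 log units; beyond the scatter), so the configuration as drawn matters on this read-out, and the gap can be put down to configuration alone because nothing else separates this pair: the fact that compounds 2 and 3 differ only in the configuration as drawn With the configuration held as drawn in compound 1, methyl in place of hydrogen on an aromatic carbon gives a 9.2-fold higher number from compound 1 to compound 3 (0.96 log units; beyond the scatter), so in this configuration that methyl goes with weaker inhibition. Compound 1 and compound 2 differ in both the methyl and the configuration, so their earlier closeness could not show either of these changes on its own.

Going by these compounds, whether the mirror image of compound 1 would part from compound 1 in the same way remains open, and so does whether the methyl step depends on the configuration. On these data alone, it is also open whether a chlorine atom or a methoxy group at the place of that methyl would follow the same course, and which of the two mirror-image forms would be favoured with such a group.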